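Adding a Second Chloro Group to a Shared Core

The compounds below may be only part of what the source reports. "The series", "measured", "known", "first", "only" and "open" are said of these compounds alone.

Three compounds have results or attempts: compound 1 `ClCc1ccccc1Cn1cnc2c(Cl)nc(Cl)nc21`, compound 2 `ClCc1ccccc1Cn1cnc2ncnc(Cl)c21` and compound 3 `ClCc1cccc(Cn2cnc3nc(Cl)nc(Cl)c32)c1`. In a functional assay on SK-MEL-28 cells (Homo sapiens) for cytotoxicity, read by sulforhodamine B assay, with a stated time of 48 h (a higher number here means that more compound is tolerated, a lower number that less compound is tolerated), compound 1 stands as "not determined" (no result reported), with no result reported. In this assay compound 2 gives 79400 nM, the higher of the two numbers, while compound 3 gives 970 nM, far lower and beyond the scatter. Compound 4 `ClCc1ccccc1Cn1cnc2nc(Cl)nc(Cl)c21` is not yet measured. It differs from compound 2 by chloro in place of hydrogen on an aromatic carbon, giving it the core of compound 3 with the side chain attached as in compound 2. Going by the values given here, no measured step covers this change. Because compound 3 reaches 970 nM, a markedly lower number is expected for compound 4, a downward step of a 16-fold lower number from compound 2 to compound 4 (1.20 log units; beyond the scatter). The estimate for compound 4 is 5000 nM, in the range 800 nM to 40000 nM.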

Compound 4, concentration lethal to 50% of the cells: > 100000 nM
Compound 4: only a limit was reported; the forecaster's own chance of this, stated with the estimate: 5%; middle value at least 20-fold (1.30 log units) away from the limit.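

In this assay, chloro in place of hydrogen on this aromatic carbon, between two ring nitrogen atoms, does not bring the lower number that compound 3 had suggested; the result is an at least 1.2-fold higher number from compound 2 to compound 4 (0.10 log units; that floor lies within the scatter). The reading for compound 4 is a limit, not a number: the limit of > 100000 nM in this assay, at which 1 of the 4 values shown sits. Compound 3 has the same core with its side chain attached differently and gives 970 nM, so the chloro alone does not settle the number on this core.

On these data alone, how an amine or a methoxy group on this same carbon would read stays open, and so does what replacing this chloro with hydrogen in compound 3 would do.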